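Swapping a Pyridylmethoxy Ether for a Furfurylamine

The compounds below may be only part of what the source reports. "The series", "measured", "known", "first", "only" and "open" are said of these compounds alone.

Within the data shown here, compound 2 `Cc1cc(OCc2ccccn2)n2nc(C)c(-c3ccccc3)c2n1` is the one compound with a full number here: in a physicochemical assay for solubility, read by HPLC, using the shake flask method, measured as kinetic solubility, with a stated time of 2 h, at pH 7.4 (a higher number here means a more soluble compound, a lower number a less soluble compound), compound 2 gives 25600 nM. Compound 1 `Cc1cc(NCc2ccccn2)n2nc(C)c(-c3ccc(F)cc3)c2n1` reaches only a limit of the assay in this assay, at < 5000 nM, which is the limit of < 5000 nM in this assay, at which 1 of the 2 values shown sits. Compound 3 `Cc1cc(NCc2ccco2)n2nc(C)c(-c3ccccc3)c2n1` has not been measured yet; it differs from compound 2 by ((furan-2-yl)methyl)amino in place of (pyridin-2-yl)methoxy on an aromatic carbon. Among the measured compounds shown here, no measured pair shares this exact change, so the expected step of a 2.1-fold lower number from compound 2 to compound 3 (0.33 log units; beyond the scatter) is a modest fall, perhaps not beyond the scatter. Compound 3 is therefore estimated at 12000 nM, within a range of 3500 nM to 35000 nM.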

Compound 3, solubility: < 5000 nM
Compound 3 was reported as a limit; the forecaster's own chance of this, stated with the estimate: 25%; middle value at least 2.4-fold (0.38 log units) away from the limit.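

Putting ((furan-2-yl)methyl)amino in place of (pyridin-2-yl)methoxy on this aromatic carbon, next to the ring nitrogen, gives in this assay an at least 5.1-fold lower number from compound 2 to compound 3 (0.70 log units; beyond the scatter). The value of compound 3 is a limit of the assay, so this step gives only its smallest size. It is the first step at this position that can be read, and it ends at the limit: the limit of < 5000 nM in this assay, at which 2 of the 3 values shown sit.

Both the ring and the atom linking it change at once, and the compounds shown do not separate the two. A (furan-2-yl)methoxy group on this carbon would pair the ring of compound 3 with the link of compound 2.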